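The source may report more compounds than this note shows. Statements on the series, on what has been measured and on what is new or still open speak of the compounds shown alone.

Within the data shown here, compound 2, with the structure `CCCNC(=O)/C=C/c1ccccc1`, is the weaker of the two measured cinnamamides: in a functional assay on the whole organism for inhibition, with Brassica rapa subsp. chinensis as the target, with a stated time of 3 days, tested at 100 ppm (on this read-out higher numbers stand for more inhibition of growth at the one concentration tested and lower numbers for less inhibition of growth), compound 2 gives 63%, the lowest of the two numbers so far. Its nearest neighbour is compound 1, with the structure `CC(C)NC(=O)/C=C/c1ccccc1`, which in this assay gives 76%. Among the measured compounds shown here, the only measured step between these two is a number 13 percentage points lower from compound 1 to compound 2 (beyond the scatter), brought about by propyl in place of isopropyl on an amide-type nitrogen.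

Compound 3, with the structure `CCCOC(=O)/C=C/c1ccccc1`, differs from compound 2 by propoxy in place of propylamino on a carbonyl carbon. For the measured compounds named here, no measured pair exchanges the amide nitrogen for an oxygen, so the single step on record speaks only to changes of the alkyl group and bears on this move indirectly; it shows that a small change at this end of the molecule can shift the read-out modestly. With nothing closer to lean on, a step of modest size in either direction, or none beyond the scatter, is plausible. Compound 3 is therefore expected at 55%, within a broad range from 30% to 80%, which corresponds to an expected step of a number 8 percentage points lower from compound 2 to compound 3 (within the scatter).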

Compound 3, percent growth inhibition at one concentration: 7%
Estimate against measurement, compound 3: 48 percentage points above; the measured number lies below the stated range.
By their numbers in this assay, from the lowest: compound 3; then compound 2; then compound 1.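

In this assay, the nature of the atom joining the chain to the carbonyl carbon proves far more telling than the shape of the alkyl group: propoxy in place of propylamino gives a number 56 percentage points lower from compound 2 to compound 3 (beyond the scatter), and propoxy in place of isopropylamino gives a number 69 percentage points lower from compound 1 to compound 3 (beyond the scatter). Among these compounds, both steps are large, whereas the only earlier step, a number 13 percentage points lower from compound 1 to compound 2 (beyond the scatter), was modest, so the amide nitrogen emerges as a sensitive point in this short series, even though the heavy-atom count of the group stays the same and the counted differences are nitrogen for oxygen and the loss of the hydrogen-bond donor. No available evidence explains why the ester falls so far behind the two amides.

The compounds shown cannot separate the role of the nitrogen itself from that of the amide hydrogen, a question that a dimethylamino group on the carbonyl carbon, which keeps nitrogen but has no such hydrogen, would address. On these data alone, it also remains open whether an isopropoxy group or a longer alkoxy chain would recover any of the inhibition seen with the amides, or whether a carboxylic acid would behave like the ester.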